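Swapping the Nitro Group for Methoxy on Compound 3

A few compounds are considered here, and "the series" means these few. Any claim that something is new, unique, unknown or untested is made for them only; others in the source may bear on it.

Of the compounds shown here, three built on a shared core have been measured so far. Compound 1 `COc1ccc(-c2nnc(CCC(=O)c3ccc(C)cc3)o2)cc1` gives 89.5% in a functional assay on the whole organism (strain Wistar) for inhibition, with Rattus norvegicus as the target, with stated times of 30 min and 3 h, at a dose of 20 mg/kg by the oral route; a higher number here means more inhibition at the dose given (going by the name of the read-out), a lower number less inhibition. Compound 2 `Cc1ccc(C(=O)CCc2nnc(-c3ccccc3)o2)c(C)c1` gives 58%, and compound 3 `Cc1ccc(C(=O)CCc2nnc(-c3ccc([N+](=O)[O-])cc3)o2)c(C)c1` gives 69.1%. Among these three numbers compound 3 stands second highest: compound 2 sits a number 11.1 percentage points higher from compound 2 to compound 3 (beyond the scatter) below it, a change brought about by a nitro group replacing a hydrogen on an aromatic carbon, while compound 1 sits clearly above it.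

Compound 4 `COc1ccc(-c2nnc(CCC(=O)c3ccc(C)cc3C)o2)cc1` has not yet been measured. The difference from compound 3 is methoxy in place of nitro on an aromatic carbon. For the measured compounds named here, no measured pair shows exactly this exchange. Going by the values given here, the one step that bears on it, a number 11.1 percentage points higher from compound 2 to compound 3 (beyond the scatter), shows that placing a nitro group on this ring lifted the readout modestly. Compound 1, which carries the same methoxy group on its core though it differs from compound 3 in more than one place, shows the highest value of the set. Taken together, a methoxy-bearing compound seems able to reach a higher readout than the nitro-bearing compound 3, so a rise beyond the scatter is expected rather than a fall.

The expected step from compound 3 to compound 4 is a number 10.9 percentage points higher from compound 3 to compound 4 (beyond the scatter). Compound 4 is thus estimated at 80%, within a range from 63% to 94%.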

Compound 4, a percentage reported as inhibition, in the whole organism at one dose (the size of the read-out at that dose, not a potency): 88.9%
Compound 4: the middle estimate sits 8.9 percentage points below what was measured, and the stated range covers the measured number.
By their numbers in this assay, from the lowest: compound 2; then compound 3; then compounds 4 and 1 (each within the scatter of the next).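

At this position, on a six-membered aromatic ring of carbon only and para to a large group, this assay now separates three groups: methoxy in place of nitro gives a number 19.8 percentage points higher from compound 3 to compound 4 (beyond the scatter), and methoxy in place of hydrogen gives a number 30.9 percentage points higher from compound 2 to compound 4 (beyond the scatter), while nitro in place of hydrogen gave only a number 11.1 percentage points higher from compound 2 to compound 3 (beyond the scatter), so hydrogen, nitro and methoxy rise in that order across these compounds. The added methyl on an aromatic carbon, by contrast, leaves no readable mark, with a number 0.6 percentage points lower from compound 1 to compound 4 (within the scatter), so this single exchange does not separate the two methoxy compounds in this read-out. Nothing available explains why methoxy outdoes nitro here.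

On these data alone, how an amine, a hydroxyl group or a longer chain such as ethoxy would fare at this same position remains open, as does whether the order of hydrogen, nitro and methoxy would hold on the core of compound 1. As far as these compounds go, since the read-out reports the size of the inhibition at one oral dose rather than a potency, it also remains open whether compound 1 and compound 4 would stay together at other doses.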